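Benzyl amide replacing a dichlorophenyl amide: cytotoxicity outlook

The source may report more compounds than this note shows. Statements on the series, on what has been measured and on what is new or still open speak of the compounds shown alone.

Measured so far:
Compound 1 `CC(CSc1nnc(-c2ccncc2)s1)C(=O)Nc1c(Cl)cccc1Cl`. In an ADME assay on BHK-21 cells (Mesocricetus auratus) for cytotoxicity, with a stated time of 3 days (on this read-out higher numbers stand for lower toxicity in this test and lower numbers for higher toxicity in this test), compound 1 gives > 50000 nM, which is a limit of the assay.
Compound 2 `CC(CSc1nnc(-c2ccncc2)s1)C(=O)Nc1ccc(Cl)cc1Cl`. In this assay compound 2 gives > 50000 nM, again a limit of the assay.

Compound 2 therefore sits at the limit, as does every value shown so far (the limit of > 50000 nM in this assay, at which 2 of the 2 values shown sit). Among the measured compounds shown here, the only measured step, a step that the two limits leave unreadable from compound 1 to compound 2, cannot be read, as both ends are limits. Compound 3 `CC(CSc1nnc(-c2ccncc2)s1)C(=O)NCc1ccccc1` differs from compound 2 in one place: benzyl in place of 2,4-dichlorophenyl on an amide-type nitrogen. No readable step bears on this change, so the expectation rests on the fact that both measured compounds reached the limit without showing toxicity. On that basis compound 3 is expected to behave alike, with an estimated value of 60000 nM and a range from 20000 nM to 200000 nM. The expected step, a step that the limit leaves unreadable from compound 2 to compound 3, is essentially none beyond the scatter.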

Compound 3, half-maximal cytotoxic concentration: > 50000 nM
Compound 3: only a limit was reported; the forecaster's own chance of this, stated with the estimate: 80%; the middle value is on the limit's open side.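

Compound 3 also gives a limit of the assay, so none of the steps linking compound 1, compound 2 and compound 3 can be read, and no size can be put on any of them: the limit of > 50000 nM in this assay, at which 3 of the 3 values shown sit.

What the compounds shown leave open is how far the true toxic concentrations of these three amides lie from that limit, and whether they differ at all.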